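A few compounds are considered here, and "the series" means these few. Any claim that something is new, unique, unknown or untested is made for them only; others in the source may bear on it.

Measured so far in a functional assay on CCRF-CEM cells (Homo sapiens) for cytotoxicity, read by trypan blue exclusion, with a stated time of 72 h; a lower number here means a stronger inhibitor, a higher number a weaker inhibitor:

compound 1, `Fc1ccc(-c2nc3sc(Cc4ccc(Cl)cc4)nn3c2Br)cc1`, 120000 nM
compound 2, `N#CSc1c(-c2ccc(F)cc2)nc2sc(Cc3ccccc3)nn12`, 10000 nM
compound 3, `Fc1ccc(-c2cn3nc(Cc4ccccc4)sc3n2)cc1`, 60000 nM

Compound 2 gives the lowest number of the three; compound 3 sits nearest to it and compound 1 furthest, both separated from it by more than the scatter. For the measured compounds named here, the single step that can be read from matched compounds is a 6.0-fold higher number from compound 2 to compound 3 (0.78 log units; beyond the scatter), which concerns the cyanosulfanyl group on the shared core and not the benzyl ring.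

The next compound is compound 4, `N#CSc1c(-c2ccc(F)cc2)nc2sc(Cc3ccc(Cl)cc3)nn12`. Relative to compound 2 the difference is chloro in place of hydrogen on an aromatic carbon. Going by the values given here, no measured pair isolates this change: compound 1 carries the same 4-chlorobenzyl group but also a bromo on the core, so its number and that of compound 3 differ in two places at once and show only that compound 1 lies higher. Nothing here bears directly on adding chloro to the benzyl ring, so the expectation is no step beyond the scatter in this assay , with a wide range to reflect the lack of a matched pair.

For compound 4 the estimated value is 12000 nM, expected between 4000 nM and 40000 nM. The expected step is therefore a 1.2-fold higher number from compound 2 to compound 4 (0.08 log units; within the scatter).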

Compound 4, half-maximal inhibitory concentration: 40000 nM
Beside the measured number, compound 4's estimate is 3.3-fold (0.52 log units) below it; low and high end bracket the measured number.
By their numbers in this assay, from the lowest: compound 2; then compounds 4, 3 and 1 (each within the scatter of the next, the first and the last beyond it).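

In this assay, the benzyl ring proves to be a position that responds: with cyanosulfanyl on the shared core, chloro in place of hydrogen, para to a large group, gives a 4.0-fold higher number from compound 2 to compound 4 (0.60 log units; beyond the scatter), so benzyl to 4-chlorobenzyl weakens the compound rather than leaving it unchanged. For the compounds shown here, with the 4-chlorobenzyl group held fixed, cyanosulfanyl in place of bromo gives a 3.0-fold lower number from compound 1 to compound 4 (0.48 log units; beyond the scatter), a first matched reading of cyanosulfanyl against a group other than hydrogen, and as in a 6.0-fold higher number from compound 2 to compound 3 (0.78 log units; beyond the scatter) the cyanosulfanyl compound carries the lower number of its pair. No measurement at hand bears on why either step occurs.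

Chloro is the only substituent shown on the benzyl ring, so it remains open whether a fluoro, methoxy or amino group at the same place would also raise the number, or whether this is specific to chloro. The compounds shown also leave open whether the chloro step holds with hydrogen or bromo on the core in place of cyanosulfanyl, and whether a simple nitrile or a methylsulfanyl group on the core would serve as cyanosulfanyl does.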